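The source may report more compounds than this note shows. Statements on the series, on what has been measured and on what is new or still open speak of the compounds shown alone.

Measured so far:
compound 1 `COc1cc(CN(C)C(=O)c2c(OCCCC3CCN(C(=O)OC(C)(C)C)CC3)c3cccnc3n(C)c2=O)cc(OC)c1` — 10000 nM
compound 2 `CN(Cc1cc(C(F)(F)F)cc(C(F)(F)F)c1)C(=O)c1c(OCCCC2CCCCC2)c2ccccc2n(C)c1=O` — 14000 nM

Both numbers come from an ADME assay for inhibition of phosphatidylcholine:ceramide cholinephosphotransferase 1 (Homo sapiens), read by mass spectrometry, with stated times of 60 min and 30 min; a higher number here means a weaker inhibitor, a lower number a stronger inhibitor. Compound 1 and compound 2 lie within the usual scatter of each other, so the two are not separated by this assay; both sit at weak inhibition.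

Compound 3 `COc1cc(CN(C)C(=O)c2c(OCCCC3CCN(C(=O)OC4(C)CC4)CC3)c3cccnc3n(C)c2=O)cc(OC)c1` has not yet been measured in this assay. It differs from compound 1 in one place: 1-methylcyclopropyl in place of tert-butyl on an oxygen next to a carbonyl group. For the measured compounds named here, no pair of measured compounds that differ in a single place is available, so there is no measured step to set the size of this change. With the rest of compound 1 kept and only the group on the oxygen next to the carbonyl exchanged, no step beyond the scatter is expected in this assay, in either direction. Compound 3 is therefore expected to give about 10000 nM, within a range from 4000 nM to 25000 nM. The expected step from compound 1 to compound 3 is no change at the digits printed from compound 1 to compound 3 (within the scatter), essentially flat.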

Compound 3, half-maximal inhibitory concentration: 18000 nM
The estimate for compound 3 lay 1.8-fold (0.26 log units) below the measured number; the measured number falls inside the stated range.
By their numbers in this assay, from the lowest: compounds 1, 2 and 3 (each within the scatter of the next).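

For the compounds shown here, the change from tert-butyl to 1-methylcyclopropyl on an oxygen next to a carbonyl group gives the only single-place step so far, a 1.8-fold higher number from compound 1 to compound 3 (0.26 log units; within the scatter), in this assay. Adding a three-membered ring at an equal count of heavy atoms therefore does not separate the two compounds, and both remain weak inhibitors. No measurement available bears on the reason for this result.

Going by these compounds alone, this pair compares only two groups made of carbon alone, so the response to an amine or a carboxylic acid in place of tert-butyl remains open. Also open, as far as these compounds go, is whether replacing the whole tert-butoxycarbonyl, for example with acetyl, would move the number clearly away from that of compound 1 (10000 nM).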